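The compounds below may be only part of what the source reports. "The series", "measured", "known", "first", "only" and "open" are said of these compounds alone.

In a functional assay on EL4 cells (Mus musculus) for antiproliferative activity, read by sulforhodamine B assay, with a stated time of 48 h (on this read-out higher numbers stand for weaker inhibition and lower numbers for stronger inhibition), compound 1 `CC1(C)[C@@H]2CC3=N[C@@H](CCC(=O)O)C(=O)O[C@@]3(C)[C@H]1C2` gives 36000 nM and compound 2 `CC(C)(C)OC(=O)CC[C@H]1N=C2C[C@H]3C[C@H](C3(C)C)[C@@]2(C)OC1=O` gives 51000 nM, two values within the scatter of each other, so compound 2 stands level with compound 1. Compound 3 `CC(C)(C)OC(=O)CC[C@@H]1N=C2C[C@@H]3C[C@@H](C3(C)C)[C@]2(C)OC1=O` has the same atoms and bonds as compound 2: the two compounds have the same atoms and bonds and differ only in configuration as drawn: 4 of 4 stereo elements differ (all stereocentres are inverted: mirror images); a stereocentre at a saturated ring carbon is drawn R in compound 2 and S in compound 3; a stereocentre at a saturated ring carbon is drawn R in compound 2 and S in compound 3; a stereocentre at a saturated ring carbon is drawn R in compound 2 and S in compound 3; a stereocentre at a saturated ring carbon is drawn R in compound 2 and S in compound 3. All stereocentres are inverted, making the two mirror images. Among the measured compounds shown here, no measured pair shows what such an inversion does in this assay, so no step beyond the scatter is expected, in either direction, and the expectation stays close to compound 2 at 51000 nM. The expected step is a 1.1-fold lower number from compound 2 to compound 3 (0.05 log units; within the scatter). For compound 3 the estimated value is 45000 nM, within an expected range of 20000 nM to 100000 nM.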

Compound 3, half-maximal inhibitory concentration: 36000 nM
Compound 3: middle estimate off by 1.3-fold (0.10 log units), on the high side; the measured number falls inside the stated range.
By their numbers in this assay, from the lowest: compounds 1, 3 and 2 (each within the scatter of the next).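

In this assay, among the compounds shown here, inverting all the stereocentres gives a 1.4-fold lower number from compound 2 to compound 3 (0.15 log units; within the scatter), so this mirror-image pair shows no separation by configuration, something the earlier compounds could not test. Among compounds of the same drawn configuration, tert-butyl in place of hydrogen on an oxygen next to a carbonyl group gives no change at the digits printed from compound 1 to compound 3 (within the scatter). The reading of the change as one of configuration alone rests on this: the fact that compounds 2 and 3 differ only in the configuration as drawn

Going by these compounds, what a methyl ester or an amide in place of the tert-butyl ester would give in this assay remains open.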